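This account rests on a few compounds, and the source may have more. Where it says the series, first, only, none or still open, it means among the compounds named here.

Compound 1 `CC(C(=O)NCc1ccc(C(F)(F)F)cc1N1CCCC1)c1ccc(NS(C)(=O)=O)c(F)c1` carries the highest number of the three measured here: in an assay on CHO cells for antagonist activity at transient receptor potential cation channel subfamily V member 1 (Homo sapiens), read by FLIPR (a lower number here means a stronger inhibitor, a higher number a weaker inhibitor), compound 1 gives 2.3 nM, while compound 2 `CC1CCN(c2cc(C(F)(F)F)ccc2CNC(=O)C(C)c2ccc(NS(C)(=O)=O)c(F)c2)CC1` gives 0.9 nM and compound 3 `CC(C(=O)NCc1ccc(C(F)(F)F)cc1OC1CCCC1)c1ccc(NS(C)(=O)=O)c(F)c1` gives 0.6 nM. Compound 4 `CC(C(=O)NCc1ccc(C(F)(F)F)cc1OCc1ccccc1)c1ccc(NS(C)(=O)=O)c(F)c1` differs from compound 1 at one place: benzyloxy in place of pyrrolidin-1-yl on an aromatic carbon. Two measured steps start from compound 1 and exchange the same pyrrolidin-1-yl: a 2.6-fold lower number from compound 1 to compound 2 (0.41 log units; beyond the scatter) and a 3.8-fold lower number from compound 1 to compound 3 (0.58 log units; beyond the scatter), both modest and beyond the scatter, whereas a 1.5-fold lower number from compound 2 to compound 3 (0.18 log units; within the scatter) stays within the scatter. The cyclopentyloxy of compound 3 is the closer precedent to the benzyloxy entering here. For compound 4 a modest lower number is therefore expected, a 2.3-fold lower number from compound 1 to compound 4 (0.36 log units; beyond the scatter). Compound 4 is estimated at 1 nM in this assay, with a range from 0.4 nM to 2.5 nM.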

Compound 4, inhibition constant: 0.9 nM
Beside the measured number, compound 4's estimate is 1.1-fold (0.05 log units) above it, and the stated range covers the measured number.
By their numbers in this assay, from the lowest: compounds 3, 2 and 4 (each within the scatter of the next); then compound 1.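

Replacing pyrrolidin-1-yl with benzyloxy gives a 2.6-fold lower number from compound 1 to compound 4 (0.41 log units; beyond the scatter) and so places a third replacement at this position beyond the scatter of compound 1. A six-membered aromatic ring of carbon only is accommodated here with no separation from the non-aromatic rings, as benzyl in place of cyclopentyl on the oxygen gives a 1.5-fold higher number from compound 3 to compound 4 (0.18 log units; within the scatter) and benzyloxy in place of 4-methylpiperidin-1-yl gives no change at the digits printed from compound 2 to compound 4 (within the scatter) in the same series. No measurement at hand bears on why compound 1 stands apart. Still open, going by these compounds, is whether methoxy, dimethylamino or the longer phenethyloxy would keep numbers in this range.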